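The source may hold more compounds than are shown below. What is called first, only, known or untested is meant among the compounds shown, and "the series" means these compounds.

Compound 1, with the structure `CCOC(=O)C(C)C(O)(c1ccc(OC)c(OC)c1OC)c1cccc2ccccc12`, was tested in a functional assay on HCT-116 cells (Homo sapiens) for inhibition, read by sulforhodamine B assay, with a stated time of 48 h; a lower number here means a stronger inhibitor, a higher number a weaker inhibitor. There compound 1 gives > 20000 nM, which is a limit of the assay rather than a number. Compound 2, with the structure `COc1ccc(C(c2ccccc2O)c2cccc3ccccc23)c(OC)c1OC`, was tested in the same way. In this assay compound 2 gives > 20000 nM, again only a limit and not a measured number. For the measured compounds named here, compound 2 therefore stands at the limit of this assay, and the one other value shown sits at that same limit (the limit of > 20000 nM in this assay, at which 2 of the 2 values shown sit), so neither compound has been placed on a scale of potency.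

Compound 3, with the structure `C=CCOC(c1ccc(OC)c(OC)c1OC)c1cccc2ccccc12`, has not yet been measured in this assay. It differs from compound 2 in one place: allyloxy in place of 2-hydroxyphenyl on a saturated chain carbon bound to two aromatic carbons. Going by the values given here, no step between two measured compounds is available to guide the direction of this change, and the two values shown offer no order to build on. Compound 3 is expected to give about 25000 nM, within a range from 8000 nM to 80000 nM. The step that the limit leaves unreadable from compound 2 to compound 3 that this estimate implies is expected to lie within the scatter, with the result most likely reported once more as a limit.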

Compound 3, half-maximal inhibitory concentration: > 20000 nM
Compound 3: a limit, no number; the forecaster's own chance of this, stated with the estimate: 80%; the middle value does not contradict the limit.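

No step can be read from compound 2 to compound 3, because in this assay both compounds stand at a limit and not at a number: the limit of > 20000 nM in this assay, at which 3 of the 3 values shown sit.

The compounds shown leave open how potent any of them is, and whether allyloxy in place of 2-hydroxyphenyl changes inhibition at all.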